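A few compounds are considered here, and "the series" means these few. Any claim that something is new, unique, unknown or untested is made for them only; others in the source may bear on it.

Working notes on the series.

Compound 1 `CCN1CCN(c2cccc3c2CN([C@H](CCCNCc2cccs2)c2ccc(OC)c(OC)c2)C3=O)CC1` gives 18 nM in an assay on RMS13 cells for displacement of a labelled ligand from Urotensin-2 receptor (Homo sapiens), read by scintillation proximity assay; on this read-out higher numbers stand for weaker inhibition and lower numbers for stronger inhibition. Compound 2 `COc1ccc([C@@H](CCCN(C)S(=O)(=O)c2cccs2)N2Cc3c(cccc3N3CCN(C4CCC4)CC3)C2=O)cc1OC` gives 44 nM in this assay. Compound 3 `COc1ccc([C@@H](CCCN(C)S(=O)(=O)c2cccs2)N2Cc3c(cccc3N3CCN(C)CC3)C2=O)cc1OC` gives < 6 nM in this assay, which is a limit of the assay and not a number; this is the limit (the limit of < 6 nM in this assay, at which 1 of the 3 values shown sits). Of the two plain numbers in this assay, compound 1 gives the lower one, with compound 2 next above it and the gap between them beyond the scatter.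

Going by the values given here, the single measured step with one change is an at least 7.3-fold lower number from compound 2 to compound 3 (0.86 log units; beyond the scatter). That step concerns the amine nitrogen in the ring on the shared core, not the amine on the chain.

Compound 4 `CCN1CCN(c2cccc3c2CN([C@H](CCCNc2cncc(OC)n2)c2ccc(OC)c(OC)c2)C3=O)CC1` differs from compound 1 only on the chain amine: 6-methoxypyrazin-2-yl in place of (thiophen-2-yl)methyl on an amine nitrogen. Among the compounds with values here, no measured step touches that position, so nothing gives a direction for this change; the two aryl groups on the chain nitrogen in compounds 1 and 2 are paired with other changes and cannot be read on their own. In this assay a step no larger than the scatter, or a modest rise, is expected, a 2.2-fold higher number from compound 1 to compound 4 (0.35 log units; beyond the scatter). Compound 4 is therefore estimated at 40 nM in this assay, within 10 nM to 160 nM.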

Compound 4, inhibition constant: 8 nM
Compound 4: middle estimate off by 5.0-fold (0.70 log units), on the high side, and the stated range ends above it.
By their numbers in this assay, from the lowest: compound 4; then compound 1; then compound 2. At a limit, below all of these: compound 3.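

In this assay, the chain amine now has its first measured step that can be read on its own: a 2.3-fold lower number from compound 1 to compound 4 (0.35 log units; beyond the scatter). The step is modest but beyond the scatter, and it shows that this amine nitrogen tolerates a change from (thiophen-2-yl)methyl to 6-methoxypyrazin-2-yl, a six-membered aromatic ring with 2 hetero atoms in place of a five-membered one with 1, with no loss of inhibition. Any further fall at this position could be read only as far as the assay allows, and compound 3 stands at a limit of the assay and not at a number: the limit of < 6 nM in this assay, at which 1 of the 4 values shown sits.

This one step changes the ring, removes the methyl link and adds the methoxy group all at once, so it cannot tell which of these goes with the lower number; a plain pyrazin-2-yl or a phenyl on the same amine nitrogen would help to separate them. Also open, on these data alone, is whether the step holds when the ethyl on the ring amine nitrogen gives way to a methyl or a cyclobutyl.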